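The compounds below may be only part of what the source reports. "The series", "measured", "known", "first", "only" and "open" are said of these compounds alone.

In an ADME assay on GES1 cells (Homo sapiens) for inhibition, read by MTT assay, with a stated time of 72 h (on this read-out lower numbers stand for stronger inhibition and higher numbers for weaker inhibition), three compounds sharing one core give nearly the same number: compound 1 `Cc1cc(Nc2cc(-c3ccccc3)[nH]n2)n2nc(SCc3ccc([N+](=O)[O-])cc3)nc2n1` gives 43600 nM, compound 2 `Cc1cc(Nc2cc(-c3ccccc3)[nH]n2)n2nc(SCc3ccccc3Br)nc2n1` gives 41100 nM, and compound 3 `Cc1cc(Nc2cc(-c3ccccc3)[nH]n2)n2nc(SCCCc3ccccc3)nc2n1` gives 40200 nM. Compound 3 therefore stands level with the other two. Compound 4 `Cc1cc(Nc2cc(-c3ccccc3)[nH]n2)n2nc(SCc3cccc4ccccc34)nc2n1`, not yet measured, carries naphthalen-1-yl in place of phenethyl on a saturated chain carbon bound to a sulfur. Three measured swaps at that place bear on it: a 1.1-fold lower number from compound 1 to compound 2 (0.03 log units; within the scatter), a 1.1-fold lower number from compound 1 to compound 3 (0.04 log units; within the scatter) and a 1.0-fold lower number from compound 2 to compound 3 (0.01 log units; within the scatter), all within the scatter. For the measured compounds named here, no measured compound carries naphthalen-1-yl, so the range stays wide. The estimate amounts to a 1.1-fold lower number from compound 3 to compound 4 (0.02 log units; within the scatter), so no step beyond the scatter is expected in this assay, in either direction. For compound 4 the estimated value is 38000 nM, with an expected range of 20000 nM to 65000 nM.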

Compound 4, half-maximal inhibitory concentration: 36300 nM
Estimate against measurement, compound 4: 1.0-fold (0.02 log units) above; low and high end bracket the measured number.
By their numbers in this assay, from the lowest: compounds 4, 3, 2 and 1 (each within the scatter of the next).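

In this assay, bringing in naphthalen-1-yl, with its 2 six-membered aromatic rings of carbon only, gives a 1.1-fold lower number from compound 3 to compound 4 (0.04 log units; within the scatter), a 1.1-fold lower number from compound 2 to compound 4 (0.05 log units; within the scatter) and a 1.2-fold lower number from compound 1 to compound 4 (0.08 log units; within the scatter). The numbers at this place, on a saturated chain carbon bound to a sulfur, therefore stay level even with this larger group of 10 heavy atoms. Nothing at hand explains this flatness. As far as these compounds go, all four groups carry an aromatic ring of carbon only, so the effect of an amine or a carboxylic acid at this place remains open. Changes elsewhere on the shared core remain open too.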